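Aryl variation on the isoxazole of a triazole-piperidine series

The source may report more compounds than this note shows. Statements on the series, on what has been measured and on what is new or still open speak of the compounds shown alone.

Measured in a functional assay on MDA-MB-468 cells (Homo sapiens) for cytotoxicity, with a stated time of 48 h; a lower number here means a stronger inhibitor, a higher number a weaker inhibitor:
compound 1 `N#Cc1ccc(-c2cc(COC(Cc3cn(C4CCN(Cc5ccc([N+](=O)[O-])cc5)CC4)nn3)c3ccc(Br)cc3)on2)cc1` gives 5000 nM.
compound 2 `O=[N+]([O-])c1ccc(CN2CCC(n3cc(CC(OCc4cc(-c5cccc(Br)c5)no4)c4ccc(Br)cc4)nn3)CC2)cc1` is reported only as a limit, > 25000 nM.
compound 3 `COc1cccc(-c2cc(COC(Cc3cn(C4CCN(Cc5ccc([N+](=O)[O-])cc5)CC4)nn3)c3ccc(Br)cc3)on2)c1` is likewise reported only as a limit, > 25000 nM.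

Compound 3 therefore sits at the limit of > 25000 nM in this assay, at which 2 of the 3 values shown sit, with no number of its own. Compound 4 `COc1ccccc1-c1cc(COC(Cc2cn(C3CCN(Cc4ccc([N+](=O)[O-])cc4)CC3)nn2)c2ccc(Br)cc2)on1` differs from it by 2-methoxyphenyl in place of 3-methoxyphenyl on an aromatic carbon. Among the measured compounds shown here, no measured step touches this change: an at least 5.0-fold higher number from compound 1 to compound 2 (0.69 log units; beyond the scatter) and an at least 5.0-fold higher number from compound 1 to compound 3 (0.69 log units; beyond the scatter) replace the 4-cyanophenyl wholesale, while a step that the two limits leave unreadable from compound 2 to compound 3. Nothing shown separates methoxy positions, so compound 4 is expected close to compound 3, meaning a number no higher from compound 3 to compound 4 (the limit leaves the size open). Compound 4 is estimated at 25000 nM, in the range 8000 nM to 60000 nM, most likely again only a limit.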

Compound 4, half-maximal inhibitory concentration: > 25000 nM
Compound 4: only a limit was reported (the forecaster's own chance of this, stated with the estimate: 65%); the middle value lies on the limit itself.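

Compound 4 is again reported only as a limit, > 25000 nM. With 2-methoxyphenyl in place of 4-cyanophenyl, the result is an at least 5.0-fold higher number from compound 1 to compound 4 (0.69 log units; beyond the scatter), so neither methoxyphenyl isomer shown reaches a measurable value in this assay. The steps to compound 4 from compound 2 and from compound 3 cannot be read, and the aryl variants now gather at one ceiling: the limit of > 25000 nM in this assay, at which 3 of the 4 values shown sit.

Among the compounds shown here, compound 1 remains the only one with a number, so its nitrile and its ring position cannot be separated. A 3-cyanophenyl or 4-methoxyphenyl group on the same carbon would be needed to tell which of the two goes with the measurable value.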